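The compounds below may be only part of what the source reports. "The series", "measured", "known", "first", "only" and "open" are said of these compounds alone.

Compound 1 `COc1cccc(OC)c1OCCNCCOc1ccccc1OCc1cccc(Cl)c1` belongs to a small set of three analogues that share one core and differ only in the group carried on a saturated chain carbon bound to an oxygen on an aromatic ring. In a functional assay on Vas deferens for antagonist activity at Alpha-1A adrenergic receptor (Rattus norvegicus) (on this read-out lower numbers stand for lower potency and higher numbers for higher potency (the scale is a negative logarithm)), compound 1 gives 8.12, the lowest of the three numbers, though both neighbours stand within the scatter of it: compound 2 `COc1cccc(OC)c1OCCNCCOc1ccccc1OCc1ccc(Cl)cc1` gives 8.17 and compound 3 `COc1cccc(OC)c1OCCNCCOc1ccccc1OCc1cccc(C)c1` gives 8.3. The change leading to compound 4 `COc1cccc(OC)c1OCCNCCOc1ccccc1OCc1ccccc1[N+](=O)[O-]` is 2-nitrophenyl in place of 3-chlorophenyl on a saturated chain carbon bound to an oxygen on an aromatic ring. Among the measured compounds shown here, two measured steps touch the same phenyl group: shifting the chloro to another place on the ring, a number 0.05 log units higher from compound 1 to compound 2 (within the scatter), and exchanging chloro for methyl, a number 0.18 log units higher from compound 1 to compound 3 (within the scatter), both stayed within the scatter, as did the step of a number 0.13 log units higher from compound 2 to compound 3 (within the scatter). None of these introduced a nitro group or a 2-nitrophenyl, so for that part of the change there is no direct guide in the data. Since every alteration tried on this phenyl so far has left this assay essentially unmoved, a step of about a number 0.12 log units lower from compound 1 to compound 4 (within the scatter) is expected, with a range widened for the untried group. The estimate for compound 4 is 8, lying between 7.4 and 8.6.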

Compound 4, negative logarithm of the antagonist equilibrium constant: 8.2
Compound 4: the middle estimate sits 0.20 log units below what was measured; measured number inside the range.
By their numbers in this assay, from the lowest: compounds 1, 2, 4 and 3 (each within the scatter of the next).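

The 2-nitrophenyl group extends the flat picture at this position to a quite different substituent. In this assay the exchange gives a number 0.08 log units higher from compound 1 to compound 4 (within the scatter), a number 0.03 log units higher from compound 2 to compound 4 (within the scatter) and a number 0.10 log units lower from compound 3 to compound 4 (within the scatter), so all four compounds fall within the scatter of their neighbours in the ranking, even though the entering group brings more heavy atoms, two hydrogen-bond acceptors where 3-chlorophenyl has none, and a double bond outside aromatic rings. No supporting evidence is available to explain this result.

The step to compound 4 alters both the substituent and its place on the phenyl, so the compounds shown cannot separate these two changes, and a nitro group placed as the chloro is in compound 1 or compound 2 would be needed to do so. They also leave open whether this position stays as flat with a carboxylic acid or an amine on the phenyl, or with a longer chain in place of the benzyl link to the oxygen on the aromatic ring.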